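The source may report more compounds than this note shows. Statements on the series, on what has been measured and on what is new or still open speak of the compounds shown alone.

Of the compounds shown here, three with a shared core have been measured in an assay on isolated protein for binding affinity to adenosine receptor A1 (Bos taurus); a lower number here means a stronger inhibitor, a higher number a weaker inhibitor. Compound 1 `OCCNc1nc(-c2ccccc2)nc2c1nnn2Cc1ccccc1` gives 38000000 nM. Compound 2 `FC(F)(F)c1ccccc1Cn1nnc2c(NC3CCCCC3)nc(-c3ccccc3)nc21` gives 6800000 nM, and compound 3 `Fc1ccccc1Cn1nnc2c(NC3CCCCC3)nc(-c3ccccc3)nc21` gives 1150000 nM, the lowest of the three numbers; the step of a 5.9-fold lower number from compound 2 to compound 3 (0.77 log units; beyond the scatter) separates it from compound 2, and compound 1 stands much further above it.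

Compound 4 `CNc1nc(-c2ccccc2)nc2c1nnn2Cc1ccccc1F` differs from compound 3 in one place: methyl in place of cyclohexyl on a nitrogen on an aromatic ring. Within the data shown here, no measured step bears directly on this change. Among the measured compounds shown here, the only single step known, between compound 2 and compound 3, concerns a substituent on an aromatic carbon, not the amino group. Compound 1, which carries a smaller amino substituent than compound 3 but also lacks the fluoro, sits far higher, and this is the only hint available; it cannot be separated into its two parts. The number for compound 4 is therefore expected to rise, by about an 8.7-fold higher number from compound 3 to compound 4 (0.94 log units; beyond the scatter), with wide uncertainty. Compound 4 is estimated at 10000000 nM, within 2000000 nM to 50000000 nM.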

Compound 4, inhibition constant: 25000000 nM
Estimate against measurement, compound 4: 2.5-fold (0.40 log units) below, and the stated range covers the measured number.
By their numbers in this assay, from the lowest: compound 3; then compound 2; then compounds 4 and 1 (each within the scatter of the next).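

The change from cyclohexylamino to methylamino gives a 22-fold higher number from compound 3 to compound 4 (1.34 log units; beyond the scatter) in this assay, the first single-place step measured on this nitrogen. It shows that this position matters to the number, and that keeping cyclohexyl there goes with the lower value in this pair. This step is also larger than a 5.9-fold lower number from compound 2 to compound 3 (0.77 log units; beyond the scatter), so among the steps shown, the change on the nitrogen moves the number further than the change on the aromatic carbon, though no information is available on why the number rises.

The compounds shown leave open how the number behaves between these two extremes, for instance with ethyl, isopropyl or cyclopentyl on the nitrogen, and so whether the ring or the carbon count matters. They also leave open whether the same step would hold with trifluoromethyl in place of fluoro.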